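The source may report more compounds than this note shows. Statements on the series, on what has been measured and on what is new or still open speak of the compounds shown alone.

Three compounds share one core and were tested in a functional assay on Hep 3B2 cells (Homo sapiens) for cytotoxicity, read by sulforhodamine B assay, with a stated time of 48 h; a lower number here means a stronger inhibitor, a higher number a weaker inhibitor. Compound 1 `CCn1cc(-c2nc3ccccc3[nH]2)c(=O)c2cc(F)c(N3CCNCC3)cc21` gives only a limit of the assay, > 10000 nM. Compound 2 `CCn1cc(-c2nc3ccc(Cl)cc3[nH]2)c(=O)c2cc(F)c(N3CCNCC3)cc21` gives 2300 nM. Compound 3 `CCn1cc(-c2nc3ccc(N)cc3[nH]2)c(=O)c2cc(F)c(N3CCNCC3)cc21` again gives only a limit, > 10000 nM. Two of the three values thus sit at the same place: the limit of > 10000 nM in this assay, at which 2 of the 3 values shown sit. The measured steps concern the aromatic ring: an at least 4.3-fold lower number from compound 1 to compound 2 (0.63 log units; beyond the scatter), while an at least 4.3-fold higher number from compound 2 to compound 3 (0.63 log units; beyond the scatter). Compound 4 `CCn1cc(-c2nc3ccc(N)cc3[nH]2)c(=O)c2cc(F)c(N3CCN(C)CC3)cc21` differs from compound 3 in another part of the molecule: methyl in place of hydrogen on an amine nitrogen in a ring. Within the data shown here, none of the measured steps touches this ring nitrogen, so the size of the step cannot be read from them. Compound 4 is therefore expected to remain near the limit, a number no higher from compound 3 to compound 4 (the limit leaves the size open). The estimate for compound 4 in this assay is 10000 nM, between 4000 nM and 30000 nM.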

Compound 4, half-maximal inhibitory concentration: > 10000 nM
Compound 4: only a limit was reported; the forecaster's own chance of this, stated with the estimate: 70%; the middle value sits exactly at the limit.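

Compound 3 and compound 4 both stop at a limit of the assay, so no step between them can be read: the limit of > 10000 nM in this assay, at which 3 of the 4 values shown sit.

Going by these compounds, what the change from piperazin-1-yl to 4-methylpiperazin-1-yl does to the number in this assay stays open.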